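Iodo to Trifluoromethyl: Expected Inhibition for Compound 4

The compounds below may be only part of what the source reports. "The series", "measured", "known", "first", "only" and "open" are said of these compounds alone.

Three compounds have been measured in a functional assay on NCI-H520 cells (Homo sapiens) for inhibition, read by MTT assay, with a stated time of 48 h, tested at 10 uM; on this read-out higher numbers stand for more inhibition at the one concentration tested (going by the name of the read-out) and lower numbers for less inhibition:
compound 1, `COc1cc(NC(=O)Nc2cc(Nc3cc(Br)ccc3OC)ncn2)cc(OC)c1`: 43.5%
compound 2, `COc1ccc(C(F)(F)F)cc1Nc1cc(NC(=O)Nc2c(Cl)cccc2Cl)ncn1`: 33%
compound 3, `COc1cc(NC(=O)Nc2cc(Nc3cc(I)ccc3OC)ncn2)cc(OC)c1`: 55%

Compound 3 stands highest of the three; the nearest number is compound 1, reached by the step of a number 11.5 percentage points higher from compound 1 to compound 3 (beyond the scatter), and compound 2 lies furthest below. Compound 4, `COc1cc(NC(=O)Nc2cc(Nc3cc(C(F)(F)F)ccc3OC)ncn2)cc(OC)c1`, differs from compound 3 by trifluoromethyl in place of iodo on an aromatic carbon. Among the compounds with values here, the only measured step, a number 11.5 percentage points higher from compound 1 to compound 3 (beyond the scatter), exchanges one halogen for another and so bears only loosely on a change to trifluoromethyl. Compound 2, which carries a trifluoromethyl on that ring but a different urea partner, gives 33% in this assay, the lowest number seen. A modest downward step, a number 10 percentage points lower from compound 3 to compound 4 (within the scatter), is therefore expected. Compound 4 is estimated at 45%, in the range 25% to 65%.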

Compound 4, a percentage reported as inhibition, at one concentration (the size of the read-out at that concentration, not a potency): 63%
Compound 4: the middle estimate sits 18 percentage points below what was measured; measured number inside the range.
By their numbers in this assay, from the lowest: compound 2; then compound 1; then compounds 3 and 4 (each within the scatter of the next).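

At this position, para to a methoxy group, trifluoromethyl and iodo cannot be told apart in this assay (a number 8 percentage points higher from compound 3 to compound 4 (within the scatter)), whereas trifluoromethyl clears bromo (a number 19.5 percentage points higher from compound 1 to compound 4 (beyond the scatter)). The low number of compound 2 therefore does not go with trifluoromethyl alone: with that group held fixed, 3,5-dimethoxyphenyl in place of 2,6-dichlorophenyl on the urea gives a clear change (a number 30 percentage points higher from compound 2 to compound 4 (beyond the scatter)). From the compounds shown here alone, whether an amine, a carboxylic acid or a nitrile at this position would keep the number at this level remains open. Nothing available gives a reason for these differences.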